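The source may report more compounds than this note shows. Statements on the series, on what has been measured and on what is new or still open speak of the compounds shown alone.

Compound 1 `Cc1ccc(OC[C@@H]2[C@H]3CC[C@H](c4nc(C(=O)O)cs4)O[C@H]3C[C@H]2O)cc1`: 27 nM
Compound 2 `O=C(O)c1csc([C@H]2CC[C@@H]3[C@@H](COc4cccc(F)c4)[C@H](O)C[C@@H]3O2)n1`: 5.4 nM

For the measured compounds named here, in a functional assay on CHO cells for agonist activity at prostaglandin E2 receptor EP2 subtype (Homo sapiens), read by HTRF and cAMP accumulation, with a stated time of 30 min (a lower number here means that less compound is needed, a higher number that more compound is needed for the effect), compound 2 gives the lower of the two numbers, and its only neighbour, compound 1, gives 27 nM. That gap is a 5.0-fold lower number from compound 1 to compound 2 (0.70 log units; beyond the scatter). Compound 3 `O=C(O)c1csc([C@H]2CC[C@@H]3[C@@H](COc4ccc(F)cc4)[C@H](O)C[C@@H]3O2)n1` differs from compound 2 by 4-fluorophenyl in place of 3-fluorophenyl on an oxygen on a saturated carbon. Going by the values given here, the single measured step, a 5.0-fold lower number from compound 1 to compound 2 (0.70 log units; beyond the scatter), combines a change of the group with a change of its position, so moving the fluorine alone has no direct precedent. A modest upward step, a 2.0-fold higher number from compound 2 to compound 3 (0.31 log units; beyond the scatter), is expected. Compound 3 is accordingly estimated at 11 nM, with a range from 3.5 nM to 40 nM.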

Compound 3, half-maximal effective concentration: 7 nM
The estimate for compound 3 lay 1.6-fold (0.20 log units) above the measured number; the range from low to high includes it.
By their numbers in this assay, from the lowest: compounds 2 and 3 (each within the scatter of the next); then compound 1.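

Compound 3 separates what the earlier step had combined. In this assay, fluoro in place of methyl on an aromatic carbon alone gives a step beyond the scatter (a 3.9-fold lower number from compound 1 to compound 3 (0.59 log units; beyond the scatter)), whereas 4-fluorophenyl in place of 3-fluorophenyl gives one within it (a 1.3-fold higher number from compound 2 to compound 3 (0.11 log units; within the scatter)), so among these compounds the fluorine's place on the ring makes no measurable difference. Nothing available explains either step. From the compounds shown here alone, whether chloro or methoxy at this place would match fluoro remains open, as does the effect of a 3-methylphenyl group.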